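Notes on anilino against pyrrolidinyl analogues of the shared core

The compounds below may be only part of what the source reports. "The series", "measured", "known", "first", "only" and "open" are said of these compounds alone.

Measured so far:
compound 1 `COc1cccc(NC2=CC(=O)c3c(nc4n3[C@H]3OC[C@@H](O)[C@H]3OC4)C2=O)c1` in a functional assay on HeLa cells (Homo sapiens) for inhibition, read by sulforhodamine B assay (on this read-out lower numbers stand for stronger inhibition and higher numbers for weaker inhibition), gives > 8000 nM, a limit.
compound 2 `COc1ccc(NC2=CC(=O)c3c(nc4n3[C@H]3OC[C@@H](O)[C@H]3OC4)C2=O)cc1` in this assay gives > 8000 nM, a limit.
compound 3 `O=C1C(N2CCCC2)=CC(=O)c2c1nc1n2[C@H]2OC[C@@H](O)[C@H]2OC1` in this assay gives > 16000 nM, a limit.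

Compound 3 thus stands only at a limit, as do the two others; the step that the two limits leave unreadable from compound 1 to compound 3 and the step that the two limits leave unreadable from compound 2 to compound 3 cannot be read, and the step that the two limits leave unreadable from compound 1 to compound 2 likewise. Compound 4 `O=C1C(Nc2cccc(F)c2)=CC(=O)c2c1nc1n2[C@H]2OC[C@@H](O)[C@H]2OC1` differs from compound 3 by (3-fluorophenyl)amino in place of pyrrolidin-1-yl on a double-bonded ring carbon. The anilino analogues compound 1 and compound 2 sit at the limit of > 8000 nM in this assay, at which 2 of the 3 values shown sit, so no step beyond the scatter is expected in this assay, and compound 4 is estimated to remain near 12000 nM (range 4000 nM to 40000 nM), a step of an at least 1.3-fold lower number from compound 3 to compound 4 (0.12 log units; that floor lies within the scatter) that is expected to be unreadable.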

Compound 4, half-maximal inhibitory concentration: > 8000 nM
Compound 4 gave a limit, no number; the forecaster's own chance of this, stated with the estimate: 80%; the middle value is on the limit's open side.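

In this assay compound 4 stands only at a limit, as do compound 1, compound 2 and compound 3, and its steps to all three cannot be read. The compounds shown leave open whether the group on the double-bonded ring carbon affects inhibition at all.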